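Adding a butyl group to compound 2

The source may report more compounds than this note shows. Statements on the series, on what has been measured and on what is new or still open speak of the compounds shown alone.

Compound 1 `Cc1ccccc1Sc1cccc(N)c1C#N` gives > 40000 nM (a limit)
Compound 2 `Cc1cc(O)cc(S(=O)(=O)c2cccc(N)c2C#N)c1` gives 167000 nM

Going by the values given here, in a functional assay on MT4 cells (Homo sapiens) for cytotoxicity (a lower number here means a stronger inhibitor, a higher number a weaker inhibitor), compound 2 gives 167000 nM as the only exact number so far. Compound 1 has only a limit of > 40000 nM and no exact number.

Compound 3 `CCCCOc1cc(C)cc(S(=O)(=O)c2cccc(N)c2C#N)c1` has not yet been measured. It differs from compound 2 by butyl in place of hydrogen on an oxygen on an aromatic ring, which turns hydroxy to butoxy. Among the compounds with values here, no measured step guides the size of this change. With compound 2 at 167000 nM on a scale where a lower number means stronger cytotoxicity, a clear fall in the number is expected. The estimated change is a 4.2-fold lower number from compound 2 to compound 3 (0.62 log units; beyond the scatter) in this expectation. For compound 3 the estimate is 40000 nM with an expected range from 10000 nM to 150000 nM around it.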

Compound 3, half-maximal inhibitory concentration: > 2000 nM
Compound 3: a limit, no number (the forecaster's own chance of this, stated with the estimate: 30%); the middle value lies beyond the limit too.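

In this assay compound 3 gives > 2000 nM, which is a limit and not a number. The change from compound 2 to compound 3 therefore cannot be read. The compounds shown leave open whether butyl in place of hydrogen lowers the number, raises it, or leaves it unchanged.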